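This account rests on a few compounds, and the source may have more. Where it says the series, first, only, none or still open, it means among the compounds named here.

Compound 1 `COC(=O)c1c(-c2cc(OC)cc(OC)c2)oc2ccccc2c1=O`: > 25 ug/mL
Compound 2 `COC(=O)c1c(-c2ccc(OCc3ccccc3)cc2)oc2ccc(OC)cc2c1=O`: > 25 ug/mL
Compound 3 `COc1cc(-c2oc3ccccc3c(=O)c2C(=O)O)cc(OC)c1OC`: > 25 ug/mL

All three results come from a functional assay on MCF7 cells (Homo sapiens) for cytotoxicity, read by MTT assay, with a stated time of 6 days (a lower number here means that less compound is needed, a higher number that more compound is needed for the effect), and each is a limit of the assay and not a number. Within the data shown here, the series so far offers only (the limit of > 25 ug/mL in this assay, at which 3 of the 3 values shown sit). Compound 3 thus stands with no number of its own: its > 25 ug/mL is a limit.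

Compound 4 `COc1cc(OC)cc(-c2oc3ccccc3c(=O)c2C(=O)O)c1` is the next compound to be read. It carries hydrogen in place of methoxy on an aromatic carbon of compound 3, ortho to two methoxy groups and para to a large group: hydrogen in place of methoxy on an aromatic carbon.

Among the measured compounds shown here, no measured pair differs in one place, so no measured step sizes this change. No step beyond the scatter is expected in this assay, and no direction can be favoured. A further limit is the most likely report for compound 4. The expected change is small, estimated as a step that the limit leaves unreadable from compound 3 to compound 4. For compound 4 the estimated value is 30 ug/mL, with an expected range of 15 ug/mL to 60 ug/mL.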

Compound 4, concentration for half-maximal effect: > 25 ug/mL
Compound 4: no number, only a limit (the forecaster's own chance of this, stated with the estimate: 85%); the middle value does not contradict the limit.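

Compound 4 gives > 25 ug/mL as a limit and not a number. The steps to it from compound 3 and compound 1 therefore cannot be read: the limit of > 25 ug/mL in this assay, at which 4 of the 4 values shown sit.

The compounds shown leave open whether exchanging methoxy for hydrogen at this place, or methyl for hydrogen on the oxygen, changes anything in this assay.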